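Aryl triazene series: Vero cell tolerance, working notes

The source may hold more compounds than are shown below. What is called first, only, known or untested is meant among the compounds shown, and "the series" means these compounds.

Measured in an ADME assay on Vero cells (Chlorocebus sabaeus) for cytotoxicity, read by crystal violet staining; a higher number here means that more compound is tolerated, a lower number that less compound is tolerated:
compound 1 `Cc1ccc(/N=N/N(C)c2ccccc2)cc1` gives 58000 nM
compound 2 `CN(/N=N/c1ccccc1)c1ccccc1` gives 50000 nM
compound 3 `CN(C)CCCN(/N=N/c1ccccc1)c1ccccc1` gives 35000 nM

Compound 2 and compound 1 differ by methyl in place of hydrogen on an aromatic carbon; the step is a 1.2-fold higher number from compound 2 to compound 1 (0.06 log units; within the scatter). Compound 2 and compound 3 differ by 2-(dimethylamino)ethyl in place of hydrogen on a saturated chain carbon bound to a nitrogen on an aromatic ring; the step is a 1.4-fold lower number from compound 2 to compound 3 (0.15 log units; within the scatter). Compound 3 shows the lowest of the three numbers, but all three lie within the scatter of one another, so no order among them can be claimed.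

Compound 4 `Cc1ccc(/N=N/N(CCCN(C)C)c2ccccc2)cc1` is not yet measured. It differs from compound 3 by methyl in place of hydrogen on an aromatic carbon, the same change that separates compound 2 from compound 1, with the place described in identical words; the cores of the two pairs differ as already described above for compound 2 and compound 3. The expectation for compound 4 therefore rests on the measured pair, where the change gave a 1.2-fold higher number from compound 2 to compound 1 (0.06 log units; within the scatter), a step within the scatter. Compound 4 is expected to give 42000 nM in this assay, with a likely range from 20000 nM to 85000 nM. The expected step is a 1.2-fold higher number from compound 3 to compound 4 (0.08 log units; within the scatter), essentially flat.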

Compound 4, half-maximal cytotoxic concentration: 100000 nM
Beside the measured number, compound 4's estimate is 2.4-fold (0.38 log units) below it; the whole stated range lies below it.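

In this assay, methyl in place of hydrogen on an aromatic carbon gives a 2.9-fold higher number from compound 3 to compound 4 (0.46 log units; beyond the scatter), but this step does not stand apart from the earlier step for the same change: the same change on two cores in this assay, a 1.2-fold higher number (0.06 log units; within the scatter) from compound 2 to compound 1 and a 2.9-fold higher number (0.46 log units; beyond the scatter) from compound 3 to compound 4, 2.5-fold (0.39 log units) apart, within the scatter of two such steps

The 2-(dimethylamino)ethyl change gives a 1.7-fold higher number from compound 1 to compound 4 (0.24 log units; within the scatter), and its two steps likewise do not stand apart: the same change on two cores in this assay, a 1.4-fold lower number (0.15 log units; within the scatter) from compound 2 to compound 3 and a 1.7-fold higher number (0.24 log units; within the scatter) from compound 1 to compound 4, 2.5-fold (0.39 log units) apart, within the scatter of two such steps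

Carrying the methyl change from the core of compound 2 to the core of compound 3 is therefore compatible with a common step, but this rests on one pair of steps and shows neither that the size of the step is the same on both cores nor that it depends on the core.

The compounds shown leave open whether the step from methyl extends to other groups at the same place on the ring, such as chloro, methoxy or a carboxylic acid. They also leave open whether a longer chain, or a different amine at the end of the chain, would follow the same course.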